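Chain shortening on the shared core, compound 1 to compound 3

A few compounds are considered here, and "the series" means these few. Any claim that something is new, unique, unknown or untested is made for them only; others in the source may bear on it.

Compound 1 `O=C(O)c1csc([C@H]2CC[C@@H]3[C@@H](/C=C/CCCOc4ccccc4)[C@H](O)C[C@@H]3O2)n1` is measured in a functional assay on CHO cells for agonist activity at prostaglandin E2 receptor EP4 subtype (Homo sapiens), read by HTRF and cAMP accumulation, with a stated time of 30 min; a lower number here means that less compound is needed, a higher number that more compound is needed for the effect. In this assay compound 1 gives > 10000 nM, a limit of the assay rather than a number. Compound 2 `O=C(O)c1csc([C@H]2CC[C@@H]3[C@@H](COc4ccccc4)[C@H](O)C[C@@H]3O2)n1` in this assay also gives > 10000 nM, again only a limit. Compound 3 `O=C(O)c1csc([C@H]2CC[C@@H]3[C@@H](/C=C/CCOc4ccccc4)[C@H](O)C[C@@H]3O2)n1` is not yet measured; it differs from compound 1 by phenoxy in place of phenoxymethyl on a saturated chain carbon, two bonds along the chain from a double-bonded chain carbon, a change kept within the same side chain. Because the limit of > 10000 nM in this assay, at which 2 of the 2 values shown sit, covers both measured values, no step beyond the scatter is expected. The expected step in this assay is a number no higher from compound 1 to compound 3 (the limit leaves the size open). Compound 3 is expected to give about 10000 nM in this assay, within 3000 nM to 30000 nM, most likely reported again only as a limit.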

Compound 3, half-maximal effective concentration: 1900 nM
The estimate for compound 3 lay 5.3-fold (0.72 log units) above the measured number; measured number outside the range, below it.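

In this assay, the side chain on the shared core proves responsive to this change: phenoxy in place of phenoxymethyl on a saturated chain carbon, two bonds along the chain from a double-bonded chain carbon, gives an at least 5.2-fold lower number from compound 1 to compound 3 (0.72 log units; beyond the scatter). Read one bond further out, this is 3-phenoxypropyl to 2-phenoxyethyl, and compound 3 gives the first value in the series that is a number rather than a limit. Going by these compounds, the full size of the step stays open, as compound 1 carries only a limit.

Still open, on these data alone, is whether a chloro substituent on the phenoxy ring or a tetrazole in place of the carboxylic acid would take the number lower than that of compound 3.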